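A few compounds are considered here, and "the series" means these few. Any claim that something is new, unique, unknown or untested is made for them only; others in the source may bear on it.

Measured compounds:
compound 1 `COc1cc2cc(Oc3ccc(NC(=O)Nc4cccc(C(F)(F)F)c4)cc3)c(C)nc2cc1OC`: 4150 nM
compound 2 `COc1cc2cc(Oc3ccc(NC(=O)Nc4ccc(Cl)c(C(F)(F)F)c4)cc3)c(C)nc2cc1OC`: 1840 nM

Both were run in a functional assay on MDA-MB-231 cells (Homo sapiens) for inhibition, read by sulforhodamine B assay, with a stated time of 48 h; on this read-out lower numbers stand for stronger inhibition of growth and higher numbers for weaker inhibition of growth. Going by the values given here, compound 1 gives 4150 nM, and compound 2 gives 1840 nM, the lowest of the two numbers; the single measured step, a 2.3-fold lower number from compound 1 to compound 2 (0.35 log units; beyond the scatter), separates them.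

Compound 3 `COc1cc2cc(Oc3ccc(NC(=O)Nc4ccc(Cl)c(Cl)c4)cc3)c(C)nc2cc1OC` differs from compound 2 by chloro in place of trifluoromethyl on an aromatic carbon. Among the compounds with values here, no measured pair shows this exchange itself. Within the data shown here, the one step known, a 2.3-fold lower number from compound 1 to compound 2 (0.35 log units; beyond the scatter), concerns chloro entering in place of hydrogen on the same ring, and its size is the only guide to how far a change on that ring moves the read-out in this assay. With trifluoromethyl leaving and chloro entering, nothing measured points to a direction, so a step no larger than that one is expected, and one within the scatter is at least as likely. Compound 3 is therefore estimated at 2500 nM, with a range of 1000 nM to 6000 nM. This estimate means an expected 1.4-fold higher number from compound 2 to compound 3 (0.13 log units; within the scatter).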

Compound 3, concentration for total growth inhibition: 12000 nM
Compound 3: middle estimate off by 4.8-fold (0.68 log units), on the low side; the measured number lies above the stated range.
By their numbers in this assay, from the lowest: compound 2; then compound 1; then compound 3.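

In this assay the trifluoromethyl group on this aromatic carbon, ortho to a chloro group, does not tolerate exchange for chloro: the change gives a 6.5-fold higher number from compound 2 to compound 3 (0.81 log units; beyond the scatter) and so reverses the earlier gain of a 2.3-fold lower number from compound 1 to compound 2 (0.35 log units; beyond the scatter) and more. Compound 3 also falls behind the compound without the second halogen, with a 2.9-fold higher number from compound 1 to compound 3 (0.46 log units; beyond the scatter) for the full change of aryl group, so adding chloro to this ring does not lower the number in every setting; the lower number holds for compound 2, and compound 3 goes against it. Nothing available explains why trifluoromethyl outperforms chloro here.

On these data alone, it remains open whether this place favours trifluoromethyl specifically or would also accept another group, such as a nitrile, a methyl group, a bromo group or a pentafluoroethyl group. As far as these compounds go, it is also open whether the exchange of trifluoromethyl for chloro costs as much when hydrogen stands in place of the other chloro, and whether the order of these three compounds holds in other cell lines.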